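Replacing Methylamino with Hydroxy in Compound 1

The compounds below may be only part of what the source reports. "The series", "measured", "known", "first", "only" and "open" are said of these compounds alone.

Compound 1 `CNC(=O)/C=C/c1ccncc1-c1ccc2cc[nH]c2c1`: 10400 nM
Compound 2 `COC1CN(C(=O)/C=C/c2ccncc2-c2ccc(F)cc2)C1`: "not determined" (no result reported)

For the measured compounds named here, in a functional assay on HCT-116 cells (Homo sapiens) for inhibition, read by MTT assay, with a stated time of 72 h (on this read-out lower numbers stand for stronger inhibition of growth and higher numbers for weaker inhibition of growth), compound 1 gives 10400 nM and is the only compound with a number, so it has no rank among others. Compound 2 offers no result for comparison.

Compound 3 `O=C(O)/C=C/c1ccncc1-c1ccc2cc[nH]c2c1` keeps the core of compound 1 but has hydroxy in place of methylamino on a carbonyl carbon. Going by the values given here, no measured pair shows what this exchange does in this assay, so the expectation rests only on compound 1 at 10400 nM and remains uncertain. A moderate weakening of growth inhibition is expected, with the estimated change a 2.4-fold higher number from compound 1 to compound 3 (0.38 log units; beyond the scatter) likely to be only a little beyond the usual scatter. For compound 3 the expected value is 25000 nM within an estimated range of 8000 nM to 80000 nM in this measurement.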

Compound 3, concentration for 50% growth inhibition: > 30000 nM
Compound 3 gave a limit, no number (the forecaster's own chance of this, stated with the estimate: 30%); middle value at least 1.2-fold (0.07 log units) from the limit.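

In this assay, compound 3 gives only a limit, > 30000 nM, and not a number. For the compounds shown here, this provides the first reading of a change on this carbonyl carbon, with hydroxy in place of methylamino: an at least 2.8-fold higher number from compound 1 to compound 3 (0.46 log units; beyond the scatter), which shows that the exchange of methylcarbamoyl for carboxy costs growth inhibition beyond the scatter. The full size of this step cannot be read, because it rests on a limit: the limit of > 30000 nM in this assay, at which 1 of the 3 values shown sits.

The compounds shown leave open whether another group on this carbonyl carbon, such as an unsubstituted amino group, a dimethylamino group or a longer chain on the amide nitrogen, would match or surpass methylamino. From the compounds shown here alone, whether the same exchange behaves alike on a different core also stays open, since compound 2 offers no result.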